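The source may hold more compounds than are shown below. What is called first, only, known or untested is meant among the compounds shown, and "the series" means these compounds.

Series notes. Compound 1 `COc1ccc2c(/C=C/C(=O)c3cc(OC)c(OC)c(SC)c3)c[nH]c2c1` and compound 2 `COc1cc(C(=O)/C=C/c2c[nH]c3ccccc23)cc(SC)c1OC` share one core and differ in one place, (hydrogen in place of methoxy on an aromatic carbon). In a functional assay on HeLa cells (Homo sapiens) for antiproliferative activity, read by MTT assay, with a stated time of 48 h (on this read-out higher numbers stand for weaker inhibition and lower numbers for stronger inhibition), compound 1 gives 131 nM, and in this assay compound 2 gives 159 nM; the step is a 1.2-fold higher number from compound 1 to compound 2 (0.08 log units; within the scatter). Compound 3 `COc1ccc2c(/C=C(\C)C(=O)c3cc(OC)c(OC)c([Se]C)c3)c[nH]c2c1` has a different core; how its core differs from that of compound 1 is not broken down here. In this assay compound 3 gives 21 nM, the lowest number of the three measured, with compound 1 the nearest and compound 2 the furthest, both beyond the scatter.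

Compound 4 `COc1cc(C(=O)/C(C)=C/c2c[nH]c3ccccc23)cc([Se]C)c1OC` is not yet measured. It differs from compound 3 by hydrogen in place of methoxy on an aromatic carbon, the same change as from compound 1 to compound 2, at a place described in the same words. Since that earlier step was a 1.2-fold higher number from compound 1 to compound 2 (0.08 log units; within the scatter), the step from compound 3 to compound 4 in this assay is expected to be similarly small, estimated as a 1.2-fold higher number from compound 3 to compound 4 (0.08 log units; within the scatter). Compound 4 is accordingly estimated at 25 nM in this assay, with a likely range from 12 nM to 55 nM.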

Compound 4, half-maximal inhibitory concentration: 34 nM
Compound 4: middle estimate off by 1.4-fold (0.13 log units), on the low side; the range from low to high includes it.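

In this assay, hydrogen in place of methoxy on an aromatic carbon gives a 1.6-fold higher number from compound 3 to compound 4 (0.21 log units; within the scatter). Set beside the earlier step, the change carries from one core to the other with no difference that can be told apart: the same change on two cores in this assay, a 1.2-fold higher number (0.08 log units; within the scatter) from compound 1 to compound 2 and a 1.6-fold higher number (0.21 log units; within the scatter) from compound 3 to compound 4, 1.3-fold (0.13 log units) apart, within the scatter of two such steps. This shows that the step stays small on these two pairs in this one assay; it does not show that it would stay small on any further core, and it gives no reason why the methoxy can be exchanged for hydrogen with so little effect on the number.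

The compounds shown leave open what other groups at this place, such as a hydroxyl, an amine or a longer ethoxy chain, would do on either core. They also leave open whether the step would hold in other cell lines, as all four values come from HeLa cells.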